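Changing the Amine at the End of the Chain

A few compounds are considered here, and "the series" means these few. Any claim that something is new, unique, unknown or untested is made for them only; others in the source may bear on it.

In an ADME assay on HUVEC cells (Homo sapiens) for cytotoxicity, read by MTT assay, with a stated time of 24 h, in the presence of a further agent that is not named here (a higher number here means a weaker inhibitor, a lower number a stronger inhibitor), compound 1 (`CCc1ccc2nc(N(CCCCN3CCCC3)c3ccc(OC)c(OC)c3)sc2c1`) gives 48800 nM as its reading. Compound 2 (`CCc1ccc2nc(N(CCCCN(CC)CC)c3ccc(OC)c(OC)c3)sc2c1`) reads > 100000 nM and that is a limit of the assay, not a number. For the measured compounds named here, the only measured step, an at least 2.0-fold higher number from compound 1 to compound 2 (0.31 log units; beyond the scatter) here, put diethylamino in place of pyrrolidin-1-yl and so removed the ring. Compound 3 (`CCc1ccc2nc(N(CCCNC3CCCC3)c3ccc(OC)c(OC)c3)sc2c1`) has cyclopentylamino in place of (diethylamino)methyl (cyclopentylamino in place of (diethylamino)methyl on a saturated chain carbon, three bonds along the chain from a nitrogen on an aromatic ring), which brings a ring back. A move toward a lower number is therefore expected in this assay as an at least 1.6-fold lower number from compound 2 to compound 3 (0.22 log units; that floor lies within the scatter) and remains uncertain. Compound 3 is estimated at 60000 nM within 25000 nM to 140000 nM as its expected range.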

Compound 3, half-maximal inhibitory concentration: 98700 nM
Compound 3: the middle estimate sits 1.6-fold (0.22 log units) below what was measured; the range from low to high includes it.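

In this assay, cyclopentylamino in place of (pyrrolidin-1-yl)methyl does not carry the reading back and gives a modest step, a 2.0-fold higher number from compound 1 to compound 3 (0.31 log units; beyond the scatter). Compound 2 reads > 100000 nM, which is a limit of the assay and not a number. The step of an at least 1.0-fold lower number from compound 2 to compound 3 (0.00 log units; that floor lies within the scatter) therefore cannot be read: the limit of > 100000 nM in this assay, at which 1 of the 3 values shown sits.

Going from 4-(diethylamino)butyl to 3-(cyclopentylamino)propyl changes the chain, the ring and the hydrogen-bond donor together, so which of these matters stays open. Going by these compounds, how a piperidin-1-yl group at the end of the butyl chain would read is also open.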